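The source may report more compounds than this note shows. Statements on the series, on what has been measured and on what is new or still open speak of the compounds shown alone.

For the measured compounds named here, in an ADME assay on L02 cells (Homo sapiens) for cytotoxicity, read by MTT assay, with a stated time of 24 h (a higher number here means a weaker inhibitor, a lower number a stronger inhibitor), compound 1 `CN1C/C(=C\c2cccnc2)C(=O)/C(=C/c2ccc(F)cc2Br)C1` gives 14400 nM and compound 2 `CN1C/C(=C\c2cccnc2)C(=O)/C(=C/c2ccccc2C(F)(F)F)C1` gives 14100 nM, the only two true numbers and within the scatter of each other. Compound 3 `CN1C/C(=C\c2ccc(C#N)cc2)C(=O)/C(=C/c2cccnc2)C1` reads > 20000 nM, which is a limit of the assay and not a number.

Compound 4 `CN1C/C(=C\c2ccncc2)C(=O)/C(=C/c2ccc(F)cc2Br)C1` departs from compound 1 at a single place: pyridin-4-yl in place of pyridin-3-yl on a double-bonded chain carbon bound to a double-bonded ring carbon. Going by the values given here, the one measured step, an at least 1.3-fold higher number from compound 1 to compound 3 (0.14 log units; that floor lies within the scatter), concerns a different group and leaves pyridin-3-yl untouched, so no measured step speaks to this change. No shift beyond the scatter is therefore expected in this assay. The expected size is an estimated 1.0-fold lower number from compound 1 to compound 4 (0.01 log units; within the scatter). For compound 4 the estimated value is 14000 nM, with an expected range of 8000 nM to 20000 nM.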

Compound 4, half-maximal inhibitory concentration: 12400 nM
Beside the measured number, compound 4's estimate is 1.1-fold (0.05 log units) above it, and the stated range covers the measured number.
By their numbers in this assay, from the lowest: compounds 4, 2 and 1 (each within the scatter of the next). At a limit, above all of these: compound 3.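

For the compounds shown here, this is the first measured change at this place, on a double-bonded chain carbon bound to a double-bonded ring carbon. In this assay, pyridin-4-yl in place of pyridin-3-yl gives a 1.2-fold lower number from compound 1 to compound 4 (0.06 log units; within the scatter) and so, with the 2-bromo-4-fluorophenyl group held, these two pyridine groups are not told apart here. No measurement shown accounts for this step.

Still open, going by these compounds, is whether a pyridin-2-yl or plain phenyl group at this place would move the number beyond the scatter. Also open, on these data alone, is whether the same swap reads alike with the 2-(trifluoromethyl)phenyl group of compound 2.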